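The source may report more compounds than this note shows. Statements on the series, on what has been measured and on what is new or still open speak of the compounds shown alone.

Compound 1 `Cc1ccc2c(c1)CCCN2c1nc(Cl)nc2ccccc12` and compound 2 `Cc1ccc2c(c1)CCCN2c1nc(C)nc2ccccc12` share a core and differ in one place: methyl in place of chloro on an aromatic carbon. In a functional assay on KB cells (Homo sapiens) for cytotoxicity, read by sulforhodamine B assay (a lower number here means a stronger inhibitor of growth, a higher number a weaker inhibitor of growth), compound 1 gives 48 nM, and compound 2 gives 204 nM, so the change produced a 4.3-fold higher number from compound 1 to compound 2 (0.63 log units; beyond the scatter).

Compound 3 `COc1ccc2c(c1)CCCN(c1nc(Cl)nc3ccccc13)C2` has a different core; how its core differs from that of compound 1 is not broken down here. In this assay compound 3 gives 11300 nM, the highest number among the three.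

Compound 4 `COc1ccc2c(c1)CCCN(c1nc(C)nc3ccccc13)C2` has not yet been measured. It differs from compound 3 in exactly one place: methyl in place of chloro on an aromatic carbon. Because the step of a 4.3-fold higher number from compound 1 to compound 2 (0.63 log units; beyond the scatter) was seen for the same change, a step of similar size is expected from compound 3 to compound 4, namely a 3.5-fold higher number from compound 3 to compound 4 (0.55 log units; beyond the scatter). Compound 4 is therefore estimated to give 40000 nM, most likely between 12000 nM and 150000 nM.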

Compound 4, concentration for 50% growth inhibition: 19600 nM
Compound 4: the middle estimate sits 2.0-fold (0.31 log units) above what was measured, and the stated range covers the measured number.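

In this assay, putting methyl in place of chloro gives a 1.7-fold higher number from compound 3 to compound 4 (0.24 log units; within the scatter), and this step can be set beside the one seen on the core of compound 1: the same change on two cores in this assay, a 4.3-fold higher number (0.63 log units; beyond the scatter) from compound 1 to compound 2 and a 1.7-fold higher number (0.24 log units; within the scatter) from compound 3 to compound 4, 2.5-fold (0.39 log units) apart, within the scatter of two such steps. The change therefore carries across these two cores with no difference in size that can be told apart from ordinary measurement scatter, though on the core of compound 3 the step itself also stays within that scatter. Two pairs of compounds show only this agreement and set no rule for the whole series.

Going by these compounds, it remains open whether the agreement would hold on a third core. On these data alone, it is also open whether an amine or a longer chain, placed on the same aromatic carbon between two ring nitrogen atoms, would give matching steps on both cores.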